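The source may report more compounds than this note shows. Statements on the series, on what has been measured and on what is new or still open speak of the compounds shown alone.

Working notes on the series, read in a functional assay on HeLa cells (Homo sapiens) for antiproliferative activity, read by MTT assay, with a stated time of 72 h; on this read-out higher numbers stand for weaker inhibition and lower numbers for stronger inhibition. Among the measured compounds shown here, compound 1 `COc1cc(-n2ncnc2-c2ccc(C)cc2)cc(OC)c1OC` gives 250 nM, the only actual number so far. Compound 2 `COc1cc(-c2ncnn2-c2ccc(F)cc2)cc(OC)c1OC` reads > 10000 nM, and this is a limit of the assay, not a number. For the measured compounds named here, no two measured compounds differ in one place only, so no measured step gives the size of the next change.

Next in line is compound 3 `COc1ccccc1-c1ncnn1-c1cc(OC)c(OC)c(OC)c1`, which keeps the core of compound 1 and alters one group: 2-methoxyphenyl in place of 4-methylphenyl on an aromatic carbon. Here 2-methoxyphenyl stands in place of 4-methylphenyl on an aromatic carbon of the shared core. Going by the values given here, with no direct precedent, the expectation rests on compound 1 at 250 nM as the single numerical anchor, and it stays loose. A moderate weakening beyond the scatter is expected, meaning a higher number in this assay. The estimated step runs a 3.6-fold higher number from compound 1 to compound 3 (0.56 log units; beyond the scatter). For compound 3 the expected value is 900 nM, with an estimated range of 150 nM to 6000 nM.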

Compound 3, half-maximal inhibitory concentration: > 10000 nM
Compound 3: no number, only a limit; the forecaster's own chance of this, stated with the estimate: 12%; middle value at least 11-fold (1.04 log units) from the limit.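

In this assay compound 3 reads > 10000 nM, which is a limit of the assay and not a number. This gives the series its first measured step: 2-methoxyphenyl in place of 4-methylphenyl, on an aromatic carbon between two ring nitrogen atoms, gives an at least 40-fold higher number from compound 1 to compound 3 (1.60 log units; beyond the scatter), so one change at this place is enough to take the shared core from a measured value to the end of the readable range. The step is therefore a lower bound on the change and its full size cannot be read, because the read-out stops at a limit: the limit of > 10000 nM in this assay, at which 2 of the 3 values shown sit.

Among the compounds shown here, the single step changes the substituent and its place on the phenyl ring together, so it does not show whether the loss follows the methoxy group, its place on the ring or the absence of the methyl group. From the compounds shown here alone, whether a plain phenyl, or a phenyl carrying a hydroxyl group or an amine, would keep a measurable value at this place stays open.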